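A few compounds are considered here, and "the series" means these few. Any claim that something is new, unique, unknown or untested is made for them only; others in the source may bear on it.

Measured so far, in an ADME assay on MT4 cells (Homo sapiens) for cytotoxicity, read by MTT assay, with a stated time of 4 days; a lower number here means that less compound is tolerated, a higher number that more compound is tolerated:

compound 1, `Nc1ccc2oc(-c3ccccc3)c(O)c(=O)c2c1`: 217000 nM
compound 2, `COc1cccc(-c2oc3ccc(N)cc3c(=O)c2O)c1`: 40800 nM
compound 3, `COc1c(-c2ccccc2)oc2ccc(NC(C)=O)cc2c1=O`: 200000 nM

Compound 1 and compound 2 share a core and differ by one change: methoxy in place of hydrogen on an aromatic carbon. In this assay this gave a 5.3-fold lower number from compound 1 to compound 2 (0.73 log units; beyond the scatter). Compound 3 sits on a different core; the difference between the two cores is not broken down here. In this assay compound 3 gives a number close to that of compound 1 and well apart from that of compound 2.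

Compound 4, `COc1ccccc1-c1oc2ccc(NC(C)=O)cc2c(=O)c1OC`, has not been measured. It differs from compound 3 by methoxy in place of hydrogen on an aromatic carbon. Within the data shown here, this is the same kind of change as the one from compound 1 to compound 2, not the same: in the first pair the methoxy enters meta to a large group, in the second pair ortho to a large group, and the surrounding core is not the same.

Among the measured compounds shown here, only one measured example of this kind of change exists in the set, so the expectation leans on it alone. For the measured compounds named here, for compound 4 in this assay the expected step is a 2.9-fold lower number from compound 3 to compound 4 (0.46 log units; beyond the scatter), kept smaller than the measured precedent because a 5.3-fold lower number from compound 1 to compound 2 (0.73 log units; beyond the scatter) is the only measured example of this kind of change and comes from another core and another place of entry, so a single precedent carries limited weight. Compound 4 is therefore expected to give about 70000 nM, with a likely range from 25000 nM to 200000 nM.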

Compound 4, half-maximal cytotoxic concentration: 154000 nM
Estimate against measurement, compound 4: 2.2-fold (0.34 log units) below; measured number inside the range.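

In this assay, phenyl to 2-methoxyphenyl on the core of compound 3, with the methoxy entering ortho to a large group, gave a 1.3-fold lower number from compound 3 to compound 4 (0.11 log units; within the scatter), so this pair cannot be told apart in this assay. The size of the step therefore did not carry over from one core to the other, and the gap between the two steps is larger than scatter alone would account for: the same change on two cores in this assay, a 5.3-fold lower number (0.73 log units; beyond the scatter) from compound 1 to compound 2 and a 1.3-fold lower number (0.11 log units; within the scatter) from compound 3 to compound 4, 4.1-fold (0.61 log units) apart, beyond the scatter of two such steps

Among these compounds, this shows only that a step seen on one core is a poor guide to the step on the other; it does not show which difference matters, since the two pairs differ both in the core and in where the methoxy enters, and with one pair on each core no rule for either core can be drawn.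

Still open, on these data alone, is whether methoxy at one and the same place on the phenyl of both cores would give steps of like size, and whether the step on the core of compound 3 stays this small at another place of entry. Also open, as far as these compounds go, is how other groups on that phenyl, such as fluorine, ethoxy or a carboxylic acid, would read on the two cores.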